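Replacing the trimethoxyphenyl group of compound 3

A few compounds are considered here, and "the series" means these few. Any claim that something is new, unique, unknown or untested is made for them only; others in the source may bear on it.

In a functional assay on CNE-2 cells (Homo sapiens) for antiproliferative activity, read by sulforhodamine B assay, with a stated time of 48 h (on this read-out lower numbers stand for stronger inhibition and higher numbers for weaker inhibition), compound 1 (`COc1cccc(/C=C/C(=O)/C=C(O)/C=C/c2cccc(OC)c2OC)c1OC`) gives 12800 nM and compound 2 (`COc1ccc(OC)c(/C=C/C(=O)/C=C(O)/C=C/c2cc(OC)ccc2OC)c1`) gives 14700 nM as its value, two numbers within the usual scatter of each other. Compound 3 (`COc1cccc(/C=C/C(=O)C(=Cc2cc(OC)c(OC)c(OC)c2)C(=O)/C=C/c2cccc(OC)c2OC)c1OC`) stands lowest of the three at 400 nM in this assay and is the most potent of them, beyond the scatter from both others. Compound 4 (`COc1cc(C=C(C(=O)/C=C/c2cccc(OC)c2OC)C(=O)/C=C/c2cccc(OC)c2OC)cc(Br)c1O`) alters one group of compound 3: 3-bromo-4-hydroxy-5-methoxyphenyl comes in place of 3,4,5-trimethoxyphenyl on a double-bonded chain carbon bound to a double-bonded chain carbon (3-bromo-4-hydroxy-5-methoxyphenyl in place of 3,4,5-trimethoxyphenyl on a double-bonded chain carbon bound to a double-bonded chain carbon). Among the compounds with values here, no measured pair here isolates such a change, so the data offer no direct guide. With compound 3 at 400 nM as the only close reference, a small shift toward weaker inhibition in this assay is expected, not beyond the scatter. The expected step is a 1.3-fold higher number from compound 3 to compound 4 (0.10 log units; within the scatter) on this estimate. In this assay the estimated value for compound 4 is 500 nM (expected range 170 nM to 1800 nM).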

Compound 4, half-maximal inhibitory concentration: 220 nM
The estimate for compound 4 lay 2.3-fold (0.36 log units) above the measured number; the range from low to high includes it.
By their numbers in this assay, from the lowest: compounds 4 and 3 (each within the scatter of the next); then compounds 1 and 2 (each within the scatter of the next).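

In this assay, the step of a 1.8-fold lower number from compound 3 to compound 4 (0.26 log units; within the scatter) stays within the usual scatter, so the two numbers cannot be told apart. Within the data shown here, this is the first reading at this position, on a double-bonded chain carbon bound to a double-bonded chain carbon, and it shows that 3-bromo-4-hydroxy-5-methoxyphenyl can stand in place of 3,4,5-trimethoxyphenyl with no difference beyond the scatter, even though the entering group brings bromine and a hydrogen-bond donor. Nothing measured here accounts for this outcome.

As far as these compounds go, the bromine and the hydroxy group enter together, so what each contributes alone stays open. Also open, from the compounds shown here alone, is whether a group of another kind on this phenyl ring, such as an amine or a carboxylic acid, would keep the number within the same scatter.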